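The source may hold more compounds than are shown below. What is called first, only, known or untested is meant among the compounds shown, and "the series" means these compounds.

Measured so far in a functional assay on K562 cells (Homo sapiens) for cytotoxicity, read by trypan blue exclusion, with a stated time of 96 h; on this read-out higher numbers stand for weaker inhibition and lower numbers for stronger inhibition

- compound 1 `COc1cc(OC)c(/C=C/S(=O)(=O)Cc2ccc(OC)c(N)c2)c(OC)c1` gives 2.5 nM
- compound 2 `COC(=O)C(F)(F)Nc1cc(CS(=O)(=O)/C=C/c2c(OC)cc(OC)cc2OC)ccc1OC` gives 250 nM
- compound 3 `COc1cc(OC)c(/C=C/S(=O)(=O)Cc2ccc(OC)c(NC(C)(C)C(=O)O)c2)c(OC)c1` gives 7.5 nM

Compound 3 holds the second highest of the three numbers, with compound 1 lower and compound 2 higher, and both gaps lie beyond the scatter.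

Compound 4 `COc1cc(OC)c(/C=C/S(=O)(=O)Cc2ccc(OC)c(NC(C(=O)O)c3ccccc3)c2)c(OC)c1` carries carboxy(phenyl)methyl in place of 1-carboxy-1-methylethyl on a nitrogen on an aromatic ring. Both groups are carboxy-bearing, but the entering one adds a six-membered aromatic ring.

Among the compounds with values here, the only measured step to a carboxy-bearing group on that nitrogen is a 3.0-fold higher number from compound 1 to compound 3 (0.48 log units; beyond the scatter) and it was modest. The large steps, a 100-fold higher number from compound 1 to compound 2 (2.00 log units; beyond the scatter) and a 33-fold lower number from compound 2 to compound 3 (1.52 log units; beyond the scatter), both involve difluoro(methoxycarbonyl)methyl, which compound 4 does not carry, so they bear on it only weakly. Within the data shown here, no measured compound has an aromatic ring in this group, so the direction rests on little.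

The expected outcome in this assay is a modest move toward a higher number, estimated as a 2.7-fold higher number from compound 3 to compound 4 (0.43 log units; beyond the scatter) and possibly no larger than the scatter. For compound 4 the estimated value is 20 nM (expected range 6 nM to 70 nM).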

Compound 4, half-maximal inhibitory concentration: 15 nM
Compound 4: middle estimate off by 1.3-fold (0.12 log units), on the high side; low and high end bracket the measured number.
By their numbers in this assay, from the lowest: compound 1; then compounds 3 and 4 (each within the scatter of the next); then compound 2.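

On the nitrogen on the aromatic ring, the six-membered aromatic ring of carboxy(phenyl)methyl is accepted in place of 1-carboxy-1-methylethyl in this assay, with a 2.0-fold higher number from compound 3 to compound 4 (0.30 log units; within the scatter) in this pair, so compounds 3 and 4 cannot be told apart and the added ring brings no separable shift. Compound 4 remains only a modest step from the hydrogen-bearing nitrogen, with a 6.0-fold higher number from compound 1 to compound 4 (0.78 log units; beyond the scatter) on that side, while a 17-fold lower number from compound 2 to compound 4 (1.22 log units; beyond the scatter) on the other is large and keeps compound 2, with difluoro(methoxycarbonyl)methyl, apart from the other three. No evidence on the origin of these steps is at hand.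

Compound 2 differs from compounds 3 and 4 in both its fluorines and its methyl ester, so a difluoro carboxylic acid or a plain methyl ester on this nitrogen would be needed to separate the two. Also open, going by these compounds, is whether the carboxylic acid is needed at all: an amide or a simple benzyl group in its place, or a longer chain between the nitrogen and the carboxylic acid, would test that.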